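This account rests on a few compounds, and the source may have more. Where it says the series, first, only, none or still open, it means among the compounds named here.

Compounds measured so far:
compound 1, `CCN1CCCC(NC(=O)c2c(OC)cc(C(F)(F)F)cc2C(F)(F)F)(c2ccccc2)C1`, 230 nM in an assay on cells for inhibition of sodium- and chloride-dependent glycine transporter 1 (Homo sapiens); a lower number here means that less compound is needed, a higher number that more compound is needed for the effect;
compound 2, `CN1CCCC(NC(=O)c2ccc(C(F)(F)F)cc2C(F)(F)F)(c2ccccc2)C1`, 540 nM in this assay.

On these two numbers compound 2 stands highest; its nearest neighbour is compound 1, whose value is lower by an amount beyond the usual scatter. Compound 3, `CN1CCCC(NC(=O)c2ccc(C(F)(F)F)cc2F)(c2ccccc2)C1`, differs from compound 2 by fluoro in place of trifluoromethyl on an aromatic carbon. Within the data shown here, no measured pair shows this change, so the step from compound 2 to compound 3 in this assay is an expectation only: compound 3 is estimated to give a modestly higher number, a 2.2-fold higher number from compound 2 to compound 3 (0.35 log units; beyond the scatter), with an expected value of 1200 nM and a range from 400 nM to 4000 nM.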

Compound 3, half-maximal effective concentration: 9900 nM
Estimate against measurement, compound 3: 8.3-fold (0.92 log units) below; measured number outside the range, above it.
By their numbers in this assay, from the lowest: compound 1; then compound 2; then compound 3.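

Fluoro in place of trifluoromethyl on this aromatic carbon, ortho to a large group, gives an 18-fold higher number from compound 2 to compound 3 (1.26 log units; beyond the scatter) in this assay. Among these compounds, this is the first comparison of compounds differing in one place, and it shows that the number depends strongly on which of these two groups occupies this carbon. Nothing measured here explains the size of this step. On these data alone, it remains open where chloro or methyl on the same carbon would fall relative to these two groups. As far as these compounds go, whether the step keeps its size on the core of compound 1 also remains open.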